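A few compounds are considered here, and "the series" means these few. Any claim that something is new, unique, unknown or untested is made for them only; others in the source may bear on it.

Measured in an ADME assay on L6 cells (Rattus norvegicus) for cytotoxicity; on this read-out higher numbers stand for weaker inhibition and lower numbers for stronger inhibition:
- compound 1 `CCN(CC)CC(=O)OC1CC2(N3CCCC3)CC(c3ccccc3)C1C(c1ccccc1)C2`: 49000 nM
- compound 2 `CCN(CC)CCC(=O)OC1CC2(N3CCCC3)CC(c3ccccc3)C1C(c1ccccc1)C2`: 19200 nM

Among the measured compounds shown here, compound 2 holds the lower of the only two numbers available in this assay. For the measured compounds named here, it is separated from its sole neighbour by a 2.6-fold lower number from compound 1 to compound 2 (0.41 log units; beyond the scatter), a modest difference that comes with (diethylamino)methyl in place of diethylamino on a saturated chain carbon bound to a carbonyl carbon.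

Compound 3 `O=C(CCN1CCCC1)OC1CC2(N3CCCC3)CC(c3ccccc3)C1C(c1ccccc1)C2` keeps the shared core and the chain of compound 2 and alters only the terminal amine: pyrrolidin-1-yl in place of diethylamino on a saturated chain carbon, two bonds along the chain from a carbonyl carbon. In words, pyrrolidin-1-yl stands in place of diethylamino on a saturated chain carbon, two bonds along the chain from a carbonyl carbon.

Going by the values given here, no measured pair makes this exchange. Among the compounds with values here, the one step at hand, a 2.6-fold lower number from compound 1 to compound 2 (0.41 log units; beyond the scatter), changes something else and bears on it only indirectly, as a guide to how far a small edit of this side chain has moved the number. A step no larger than that one is therefore expected, and most likely none beyond the scatter. The expected step is a 1.1-fold lower number from compound 2 to compound 3 (0.03 log units; within the scatter). For compound 3 the estimated value is 18000 nM, with an expected range of 8000 nM to 38000 nM.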

Compound 3, half-maximal inhibitory concentration: 21900 nM
Beside the measured number, compound 3's estimate is 1.2-fold (0.09 log units) below it; measured number inside the range.
By their numbers in this assay, from the lowest: compounds 2 and 3 (each within the scatter of the next); then compound 1.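

In this assay, the terminal amine on a saturated chain carbon, two bonds along the chain from a carbonyl carbon, can be diethylamino or pyrrolidin-1-yl with no difference that can be read, since the ring in the new group leaves the number within the scatter: a 1.1-fold higher number from compound 2 to compound 3 (0.06 log units; within the scatter). The modest step seen earlier is also not confined to a diethylamino end group, as (pyrrolidin-1-yl)methyl in place of diethylamino on a saturated chain carbon bound to a carbonyl carbon gives a 2.2-fold lower number from compound 1 to compound 3 (0.35 log units; beyond the scatter). Nothing at hand accounts for the two amines reading alike or for the distance of both side chains from the shorter one.

What the compounds shown leave open is whether the same reading would hold for other terminal amines at this place, such as piperidin-1-yl, morpholin-4-yl or an unsubstituted amine. They also leave open how a pyrrolidin-1-yl group would read directly on the shorter chain, and whether a longer chain, such as 3-(diethylamino)propyl, would carry the step further.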